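Compound 2 at the limit, and a fluoro added

This account rests on a few compounds, and the source may have more. Where it says the series, first, only, none or still open, it means among the compounds named here.

In a functional assay on CCRF-CEM cells (Homo sapiens) for cytotoxicity (on this read-out lower numbers stand for stronger inhibition and higher numbers for weaker inhibition), compound 1 `Nc1ccn([C@@H]2CC(F)(F)[C@H](CO)O2)c(=O)n1` gives > 100000 nM, which is a limit of the assay and not a number. Compound 2 `Nc1ccn([C@@H]2C=C(F)[C@H](CO)O2)c(=O)n1` gives > 100000 nM, also a limit. Compound 3 `Nc1ccn([C@H]2C=C(F)[C@H](CO)O2)c(=O)n1` gives > 100000 nM, again a limit. Compound 2 therefore has no number to stand on, and its position is shared by the whole set, as shown by the limit of > 100000 nM in this assay, at which 3 of the 3 values shown sit.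

Compound 4 `Nc1nc(=O)n([C@@H]2C=C(F)[C@H](CO)O2)cc1F` departs from compound 2 by one change: fluoro in place of hydrogen on an aromatic carbon, ortho to an amino group. Among the measured compounds shown here, the only measured step from compound 2 is a step that the two limits leave unreadable from compound 2 to compound 3. That step concerns (the fact that compounds 2 and 3 differ only in the configuration as drawn), not this replacement, so it offers no size to carry over.

With compound 2 resting on the limit > 100000 nM, no step beyond the scatter is expected in this assay, and no direction can be assigned. The estimated step is a number no higher from compound 2 to compound 4 (the limit leaves the size open). For compound 4 the estimated value is 100000 nM, with an expected range from 40000 nM to 200000 nM.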

Compound 4, half-maximal inhibitory concentration: > 100000 nM
Compound 4 gave a limit, no number; the forecaster's own chance of this, stated with the estimate: 85%; the middle value sits exactly at the limit.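

In this assay, among the compounds shown here, compound 4 gives > 100000 nM, a limit and not a number; compound 2 also sits at a limit, so no step between them can be read. The compounds shown leave open whether fluoro in place of hydrogen on an aromatic carbon shifts this read-out at all.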